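Ester for benzyl on the thioether chain of compound 3

This account rests on a few compounds, and the source may have more. Where it says the series, first, only, none or still open, it means among the compounds named here.

Compound 1 `COc1ccc(-n2c(SCC(=O)c3ccc(OC)c(O)c3)nnc2-c2cc(OC)c(OC)c(OC)c2)cc1` gives in a functional assay on PC-3 cells (Homo sapiens) for inhibition, read by MTT assay, with a stated time of 48 h (on this read-out lower numbers stand for stronger inhibition and higher numbers for weaker inhibition), only a limit, > 60000 nM, the point described by the limit of > 60000 nM in this assay, at which 1 of the 3 values shown sits. Compound 2 `COc1ccc(-n2c(SCC(=O)Nc3ccc(Cl)cc3)nnc2-c2cc(OC)c(OC)c(OC)c2)cc1` gives 6290 nM in this assay. Compound 3 `COc1cc(-c2nnc(SCc3ccccc3)n2-c2ccc(N(C)C)cc2)cc(OC)c1OC` gives 55800 nM in this assay, the highest of the two numbers shown, with compound 2 as its nearest neighbour. Among the compounds with values here, the only measured step, an at least 9.5-fold lower number from compound 1 to compound 2 (0.97 log units; beyond the scatter), concerns a carbonyl carbon of the side chain and does not match the change now considered. Compound 4 `CCOC(=O)CSc1nnc(-c2cc(OC)c(OC)c(OC)c2)n1-c1ccc(N(C)C)cc1` differs from compound 3 by ethoxycarbonyl in place of phenyl on a saturated chain carbon bound to a sulfur. Within the data shown here, no measured step bears on this change, so no shift beyond the scatter is expected. Compound 4 is estimated at 45000 nM, within 12000 nM to 120000 nM. The expected step is a 1.2-fold lower number from compound 3 to compound 4 (0.09 log units; within the scatter).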

Compound 4, half-maximal inhibitory concentration: > 60000 nM
Compound 4 ended at the assay's limit; the forecaster's own chance of this, stated with the estimate: 35%; middle value at least 1.3-fold (0.12 log units) away from the limit.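

In this assay, ethoxycarbonyl in place of phenyl on a saturated chain carbon bound to a sulfur gives an at least 1.0-fold higher number from compound 3 to compound 4 (0.03 log units; that floor lies within the scatter). This floor shows that the ester brings no lower number at this position, but it leaves the true size of the change unread. Compound 4 gives only a limit, not a number: the limit of > 60000 nM in this assay, at which 2 of the 4 values shown sit.

Still open, as far as these compounds go, is whether a carboxylic acid or a primary amine on this saturated chain carbon would give a lower number. A longer chain between the sulfur and the ester also remains untested among the compounds shown.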